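A few compounds are considered here, and "the series" means these few. Any claim that something is new, unique, unknown or untested is made for them only; others in the source may bear on it.

Of the compounds shown here, three that share one core have been measured in an ADME assay on the whole organism (plasma, Macaca fascicularis) for protein binding, read by LC-MS, using equilibrium dialysis and cassette dosing, with a stated time of 24 h, at a dose of 1 mg/kg by the oral route; a higher number here means a larger unbound share of the compound, a lower number a smaller unbound share. Compound 1 `CCCCN(c1nc2c(-c3nccn3C)cccc2o1)[C@H](C)c1ccc(-c2ccccc2-c2nnn[nH]2)cc1` gives 0.00299. Compound 2 `CCCCN(c1nc2c(CO)cccc2o1)[C@H](C)c1ccc(-c2ccccc2-c2nnn[nH]2)cc1` gives 0.00112. Compound 3 `CCCCN(c1nc2c(C(=O)NS(C)(=O)=O)cccc2o1)[C@H](C)c1ccc(-c2ccccc2-c2nnn[nH]2)cc1` gives 0.00103, the bottom of the three numbers, although its distance from compound 2 is within the scatter, as a 1.1-fold lower number from compound 2 to compound 3 (0.04 log units; within the scatter) shows; only compound 1 stands clearly apart, a 2.9-fold lower number from compound 1 to compound 3 (0.46 log units; beyond the scatter). Compound 4 `CCCCN(c1nc2c(-c3ccccn3)cccc2o1)[C@H](C)c1ccc(-c2ccccc2-c2nnn[nH]2)cc1` has not yet been measured in this assay. It differs from compound 3 in one place: pyridin-2-yl in place of (methylsulfonyl)carbamoyl on an aromatic carbon. Among the measured compounds shown here, the steps that bear on this change are a 2.9-fold lower number from compound 1 to compound 3 (0.46 log units; beyond the scatter) and a 2.7-fold lower number from compound 1 to compound 2 (0.43 log units; beyond the scatter), because compound 1 carries 1-methyl-1H-imidazol-2-yl at the same place and gives 0.00299. Compound 4 is therefore expected to show a modest rise in this assay, an expected 2.7-fold higher number from compound 3 to compound 4 (0.43 log units; beyond the scatter). The estimate for compound 4 is 0.0028, with a range from 0.0012 to 0.0065.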

Compound 4, unbound fraction: 0.00129
Compound 4: middle estimate off by 2.2-fold (0.34 log units), on the high side; the measured number falls inside the stated range.
By their numbers in this assay, from the lowest: compounds 3, 2 and 4 (each within the scatter of the next); then compound 1.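

In this assay, placing pyridin-2-yl on this aromatic carbon gives a 1.3-fold higher number from compound 3 to compound 4 (0.10 log units; within the scatter) and a 1.2-fold higher number from compound 2 to compound 4 (0.06 log units; within the scatter), so the aromatic ring of compound 4 cannot be told apart from the hydroxymethyl of compound 2 or the (methylsulfonyl)carbamoyl of compound 3. Compound 1 stays apart, as a 2.3-fold lower number from compound 1 to compound 4 (0.37 log units; beyond the scatter) shows, so among these compounds an aromatic ring at this place does not by itself go with the larger unbound share, and only 1-methyl-1H-imidazol-2-yl does. Nothing available here explains the gap between these two rings.

The compounds shown leave open whether the higher number of compound 1 belongs to the whole 1-methyl-1H-imidazol-2-yl group or to its methyl. They also leave open whether phenyl, an amine or a carboxylic acid on this carbon would stand with compound 1 or with the other three.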